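Swapping the chlorophenyl arm for an oxane ring

The source may report more compounds than this note shows. Statements on the series, on what has been measured and on what is new or still open speak of the compounds shown alone.

For the measured compounds named here, compound 1 `C[C@@H](Nc1c(C(N)=O)cnc2ccc(-c3cccnc3)cc12)c1ccc(Cl)cc1` is the only compound here with a numbered result: in an assay on HT-29 cells for inhibition of Serine-protein kinase ATM (Homo sapiens), read by fluorescence, with a stated time of 1 h (on this read-out higher numbers stand for weaker inhibition and lower numbers for stronger inhibition), compound 1 gives 109 nM. Compound 2 `C[C@@H](Nc1ccnc2ccc(-c3cccnc3)cc12)c1ccc(Cl)cc1` differs from it by hydrogen in place of carbamoyl on an aromatic carbon. In this assay compound 2 reaches only a limit, > 30000 nM. Going by the values given here, that step, an at least 270-fold higher number from compound 1 to compound 2 (2.43 log units; beyond the scatter), is the sole measured comparison, and its size rests on (the limit of > 30000 nM in this assay, at which 1 of the 2 values shown sits). Compound 3 `C[C@@H](Nc1c(C(N)=O)cnc2ccc(-c3cccnc3)cc12)C1CCOCC1` keeps the carbamoyl and changes the other end: oxan-4-yl in place of 4-chlorophenyl on a saturated chain carbon bound to a nitrogen on an aromatic ring and a saturated chain carbon. Among the compounds with values here, no measured step touches this position, so the carbamoyl result offers no direct guide; an aromatic ring with a halogen gives way to a saturated ring with an oxygen acceptor, and the outcome is open. The estimate for compound 3 in this assay leans toward a weaker result, a step of a 14-fold higher number from compound 1 to compound 3 (1.14 log units; beyond the scatter), giving an expected value of 1500 nM within a range from 200 nM to 15000 nM.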

Compound 3, half-maximal inhibitory concentration: 730 nM
For compound 3 the middle estimate is 2.1-fold (0.31 log units) above the measured one; low and high end bracket the measured number.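

Placing oxan-4-yl in place of 4-chlorophenyl on the saturated chain carbon weakens the result in this assay, with a 6.7-fold higher number from compound 1 to compound 3 (0.83 log units; beyond the scatter). The step is modest, and compound 3 still gives a measured number, so on the carbamoyl-bearing core this position accepts a non-aromatic ring with an oxygen, and 4-chlorophenyl is not needed for a measurable value. Nothing shown here accounts for the size of this step.

The compounds shown leave open which part of the change matters, the chlorine, the aromatic ring or the ring oxygen; an unsubstituted phenyl or a cyclohexyl at this place would pull these apart. They also leave open how a piperidin-4-yl, with a ring nitrogen in place of the oxygen, would compare with oxan-4-yl.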